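This account rests on a few compounds, and the source may have more. Where it says the series, first, only, none or still open, it means among the compounds named here.

Measured so far in a functional assay on cells for antagonist activity at C-X-C chemokine receptor type 4 (Homo sapiens), read by fluorescence and calcium flux, with stated times of 25 min and 90 s; a higher number here means a weaker inhibitor, a lower number a stronger inhibitor:
- compound 1 `c1ccc2c(c1)CN[C@@H](CN(CCCCNCC1CCSCC1)[C@H]1CCCc3cccnc31)C2`: 69.6 nM
- compound 2 `C(=C/CN(C[C@H]1Cc2ccccc2CN1)[C@H]1CCCc2cccnc21)\CNCC1CCOCC1`: 24.2 nM
- compound 3 `FC1(F)CCC(NC/C=C/CN(C[C@H]2Cc3ccccc3CN2)[C@H]2CCCc3cccnc32)CC1`: 82.1 nM

Compound 3 gives the highest number of the three in this assay; its gap to compound 1 lies within the scatter, and only compound 2 is separated from it beyond the scatter.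

Compound 4 `C(=C/CN(C[C@H]1Cc2ccccc2CN1)[C@H]1CCCc2cccnc21)\CNCc1ccccn1` is the next step: (pyridin-2-yl)methyl in place of 4,4-difluorocyclohexyl on an amine nitrogen.

Going by the values given here, two measured steps bear on this position. The step of a 2.9-fold lower number from compound 1 to compound 2 (0.46 log units; beyond the scatter) shows that swapping one methylene-linked six-membered ring for another at this amine moves the number modestly. The step of a 3.4-fold higher number from compound 2 to compound 3 (0.53 log units; beyond the scatter) shows that replacing the methylene-linked oxane ring with the directly attached difluorocyclohexyl ring raised the number modestly. Compound 4 returns to a methylene-linked six-membered ring at that amine, so a modest move back toward the number of compound 2 is expected, with the direction downward in this assay and the size expected to be a 2.6-fold lower number from compound 3 to compound 4 (0.41 log units; beyond the scatter).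

For compound 4 the expected value in this assay is 32 nM, with a range from 12 nM to 90 nM.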

Compound 4, half-maximal inhibitory concentration in the C-X-C chemokine receptor type 4 assay: 58.3 nM
Beside the measured number, compound 4's estimate is 1.8-fold (0.26 log units) below it; measured number inside the range.
By their numbers in the C-X-C chemokine receptor type 4 assay, from the lowest: compound 2; then compounds 4, 1 and 3 (each within the scatter of the next).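

In the C-X-C chemokine receptor type 4 assay compound 4 gives 58.3 nM and (pyridin-2-yl)methyl on this amine nitrogen is not separated from 4,4-difluorocyclohexyl, with a 1.4-fold lower number from compound 3 to compound 4 (0.15 log units; within the scatter) here, or from the sulfur-containing group of compound 1, with a 1.2-fold lower number from compound 1 to compound 4 (0.08 log units; within the scatter) here. A methylene-linked six-membered ring therefore does not by itself recover the number of compound 2: pyridin-2-yl in place of oxan-4-yl gives a 2.4-fold higher number from compound 2 to compound 4 (0.38 log units; beyond the scatter) as the step, so the identity of the ring matters at this position in these compounds. In a physicochemical assay for permeability, using PAMPA, with a stated time of 4 h, at pH 7.4, tested at 100 uM (a higher number here means that the compound crosses the layer faster, a lower number that the compound crosses the layer more slowly), the same change from 4,4-difluorocyclohexyl gives a 1.0-fold higher number from compound 3 to compound 4 (0.01 log units; within the scatter) as the step, which lies within the scatter: compound 3 gives 49 nm/s and compound 4 gives 50 nm/s in this assay.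

On these data alone, whether benzyl or (pyridin-3-yl)methyl on this amine nitrogen would stand with compound 2 or with compound 4 remains open. Nothing available gives a measured reason for the gap between the oxane and pyridine rings.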